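A Butyl Group Tested on the Phenyl of Compound 2

A few compounds are considered here, and "the series" means these few. Any claim that something is new, unique, unknown or untested is made for them only; others in the source may bear on it.

Of the compounds shown here, three of the shared core have been measured in a functional assay on HeLa cells (Homo sapiens) for antiproliferative activity, read by MTT assay, with a stated time of 96 h; a higher number here means a weaker inhibitor, a lower number a stronger inhibitor. Compound 1 `CN(C)c1ccc(N2C(=O)NC3(CSC4=C3C(=O)c3ncccc3C4=O)C2=O)cc1` gives 10 nM in this assay. Compound 2 `O=C1C2=C(C(=O)c3ncccc31)C1(CS2)NC(=O)N(c2ccccc2)C1=O` gives 3 nM, the lowest of the three numbers. Compound 3 `O=C1NN(c2ccc([N+](=O)[O-])cc2)C(=O)C2(CSC3=C2C(=O)c2ncccc2C3=O)N1` differs from compound 2 at several places; in this assay compound 3 gives 610 nM. Among the compounds with values here, the one step between compounds that differ in a single place is a 3.3-fold lower number from compound 1 to compound 2 (0.52 log units; beyond the scatter), hydrogen in place of dimethylamino on an aromatic carbon. Compound 2 thus stands lowest, with compound 1 nearest and compound 3 furthest off.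

The unmeasured compound 4 `CCCCc1ccc(N2C(=O)NC3(CSC4=C3C(=O)c3ncccc3C4=O)C2=O)cc1` differs from compound 2 by butyl in place of hydrogen on an aromatic carbon; cut one bond further out, the change reads phenyl to 4-butylphenyl. The step from compound 1 to compound 2 is the only one that bears on this change, since it also concerns a group on that aromatic carbon, and there the removal of dimethylamino lowered the number by a modest amount. Placing a butyl there is expected to move the number in the opposite direction, by a comparable or smaller amount, though butyl shares nothing with dimethylamino beyond its place, so the expectation is loose. Compound 4 is estimated at 7 nM, with a range of 2 nM to 30 nM. The expected step is a 2.3-fold higher number from compound 2 to compound 4 (0.37 log units; beyond the scatter).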

Compound 4, half-maximal inhibitory concentration: 90 nM
The estimate for compound 4 lay 13-fold (1.11 log units) below the measured number; the whole stated range lies below it.
By their numbers in this assay, from the lowest: compound 2; then compound 1; then compound 4; then compound 3.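

In this assay, placing butyl on this aromatic carbon gives a 30-fold higher number from compound 2 to compound 4 (1.48 log units; beyond the scatter), a step well larger than the one seen when dimethylamino gave way to hydrogen, so this position proves far less forgiving than the earlier pair suggested. Exchanging one substituent for the other at the same place gives a 9.0-fold higher number from compound 1 to compound 4 (0.95 log units; beyond the scatter), which shows that the two groups are not equivalent here and that, among the three compounds differing only at this carbon, both dimethylamino and butyl give higher numbers than hydrogen, with butyl giving the highest. Nothing available accounts for the size of this rise or for the gap between butyl and dimethylamino.

The compounds shown leave open whether the number climbs gradually with chain length, which methyl, ethyl or a longer chain such as hexyl on the same carbon would test. They also leave open whether a group carrying oxygen or nitrogen, such as methoxy, a carboxylic acid or a primary amine, would stay close to hydrogen or rise as butyl does.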